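Lengthening the Carboxy Chain of Compound 3

This account rests on a few compounds, and the source may have more. Where it says the series, first, only, none or still open, it means among the compounds named here.

Of the compounds shown here, three with a shared core have been measured in a functional assay (Saphenous vein) for inhibition, with Oryctolagus cuniculus as the target; on this read-out higher numbers stand for weaker binding and lower numbers for tighter binding. In this assay, compound 1 `O=C(O)CCc1c(-c2cccnc2)ccc2c1CCC(NS(=O)(=O)c1ccc(Cl)cc1)C2` gives 0.2 nM, and compound 2 `O=C(O)CCc1cc(Cc2cccnc2)cc2c1CCC(NS(=O)(=O)c1ccc(Cl)cc1)C2` gives 0.2 nM, so these two show the same number. Compound 3 `O=C(O)CC/C=C/c1c(Cc2cccnc2)ccc2c1CCC(NS(=O)(=O)c1ccc(Cl)cc1)C2` gives 0.00794 nM, the lowest of the three numbers and therefore the tightest binding, and the gap to each of the other two lies beyond the usual scatter.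

Compound 4 `O=C(O)CCC/C=C/c1c(Cc2cccnc2)ccc2c1CCC(NS(=O)(=O)c1ccc(Cl)cc1)C2` differs from compound 3 in one place: carboxymethyl in place of carboxy on a saturated chain carbon, two bonds along the chain from a double-bonded chain carbon. Carboxymethyl stands in place of carboxy on a saturated chain carbon, two bonds along the chain from a double-bonded chain carbon, so 4-carboxybut-1-en-1-yl becomes 5-carboxypent-1-en-1-yl.

Among the compounds with values here, no measured pair here isolates a change of this kind, so the data give no direct guide to its size. With compound 3 already at 0.00794 nM, far below the other two numbers, a modest rise seems more likely than a further fall. The expected change is a 2.5-fold higher number from compound 3 to compound 4 (0.40 log units; beyond the scatter), an estimate that points toward somewhat weaker binding and may not clear the scatter by much. In this assay, the estimate for compound 4 is 0.02 nM, with an expected range of 0.004 nM to 0.1 nM.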

Compound 4, dissociation constant: 1.26 nM
Beside the measured number, compound 4's estimate is 63-fold (1.80 log units) below it; measured number outside the range, above it.
By their numbers in this assay, from the lowest: compound 3; then compounds 1 and 2 (each within the scatter of the next); then compound 4.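

Adding a single carbon to the carboxy-bearing chain, with the carboxy group and the double bond both kept, changes 4-carboxybut-1-en-1-yl into 5-carboxypent-1-en-1-yl, and in this assay this gives a 160-fold higher number from compound 3 to compound 4 (2.20 log units; beyond the scatter). Within the data shown here, the earlier compounds offered no pair differing in one place, so this is the first direct look at this position, and it shows that even so small a change in chain length can carry a large step, here from the tightest binder of the set to the highest number. No measurement at hand bears on what lies behind a step of this size.

Going by these compounds, with a single step along this chain, no trend can be drawn yet, so it stays open whether a shorter chain such as 3-carboxyprop-1-en-1-yl or a longer one such as 6-carboxyhex-1-en-1-yl would continue the same direction. Also open, on these data alone, is how a tetrazole or a primary amide at the end of the chain, in place of the carboxylic acid, would read in this assay.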